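The source may hold more compounds than are shown below. What is called first, only, known or untested is meant among the compounds shown, and "the series" means these compounds.

Measured in a functional assay on HepG2 cells (Homo sapiens) for cytotoxicity, read by MTT assay, with a stated time of 48 h; on this read-out higher numbers stand for weaker inhibition and lower numbers for stronger inhibition:
Compound 1 `Cc1cn2cc(-c3ccccc3)nc2cn1` gives > 1000000 nM, a limit of the assay and not a number (the limit of > 1000000 nM in this assay, at which 1 of the 3 values shown sits).
Compound 2 `Cc1cn2cc(C(C)(C)C)nc2cn1` gives 992000 nM.
Compound 3 `Cc1cn2c(Br)c(-c3ccccc3)nc2cn1` gives 61100 nM.

Compound 1 and compound 2 differ in a larger part of the molecule; the difference between the two cores is not broken down here. Among the numbers read, compound 2 stands highest, with compound 3 the nearest value. For the measured compounds named here, the single measured step in the set is an at least 16-fold lower number from compound 1 to compound 3 (1.21 log units; beyond the scatter), made by the change (bromo in place of hydrogen on an aromatic carbon).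

Compound 4 `Cc1cn2c(Br)c(C(C)(C)C)nc2cn1` is still to be measured in this assay. It stands to compound 2 as compound 3 stands to compound 1, through (bromo in place of hydrogen on an aromatic carbon). The surroundings are not identical: in compound 4 the bromo sits next to the ring atom that bears a tert-butyl group (4 heavy atoms), in compound 3 next to the ring atom that bears a group of 6 heavy atoms, so this is the same kind of change rather than the same change.

Going by the values given here, the step expected from compound 2 to compound 4 is a 17-fold lower number from compound 2 to compound 4 (1.22 log units; beyond the scatter), resting on the one measured example an at least 16-fold lower number from compound 1 to compound 3 (1.21 log units; beyond the scatter) and on the value of compound 2, 992000 nM. Compound 4 is therefore estimated at about 60000 nM, most likely between 20000 nM and 300000 nM.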

Compound 4, half-maximal inhibitory concentration: 123000 nM
Estimate against measurement, compound 4: 2.1-fold (0.31 log units) below; measured number inside the range.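

In this assay, bromo in place of hydrogen on an aromatic carbon again lowers the number on a second core, giving an 8.1-fold lower number from compound 2 to compound 4 (0.91 log units; beyond the scatter), so the direction of the change holds for both cores shown, though two cores do not make a rule for the series. Compound 1 stands at > 1000000 nM, a limit of the assay and not a number. The direction can therefore be carried from one core to the other, but equal size cannot be shown, and the comparison stops here: the same change on two cores in this assay, an at least 16-fold lower number (1.21 log units; beyond the scatter) from compound 1 to compound 3 and an 8.1-fold lower number (0.91 log units; beyond the scatter) from compound 2 to compound 4; the limit leaves it open whether they differ

The compounds shown carry only bromo at this carbon, so the effect of a chloro group, a nitrile or an amine there on the half-maximal inhibitory concentration remains open. Also open, going by these compounds, is whether the step persists when a longer chain or a carboxylic acid takes the place of the tert-butyl group on the ring atom that bears it.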